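The source may hold more compounds than are shown below. What is called first, only, known or untested is meant among the compounds shown, and "the series" means these compounds.

In a functional assay for inhibition, with Homo sapiens as the target (a higher number here means weaker binding, a lower number tighter binding), three compounds built on a shared core have been measured. Compound 1 `O=C(O)CC/C=C\CC1COC(c2ccsc2)OC1c1cccnc1` gives 1580 nM, and compound 2 `O=C(O)CC/C=C\CC1COC(c2ccc3ccccc3c2)OC1c1cccnc1` gives 1780 nM. Compound 3 `COc1ccc(OC(C)(C)C2OCC(C/C=C\CCC(=O)O)C(c3cccnc3)O2)cc1`, at 302 nM, holds the lowest number of the three.

The next compound to be tested is compound 4 `CC(C)(Oc1ccccc1F)C1OCC(C/C=C\CCC(=O)O)C(c2cccnc2)O1`. It differs from compound 3 in one place: 2-fluorophenyl in place of 4-methoxyphenyl on an oxygen on a saturated carbon. Here, 2-fluorophenyl stands in place of 4-methoxyphenyl on an oxygen on a saturated carbon, so that 4-methoxyphenoxy becomes 2-fluorophenoxy.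

For the measured compounds named here, only one measured step bears on this change, and only loosely: a 1.1-fold higher number from compound 1 to compound 2 (0.05 log units; within the scatter). That step replaces thiophen-3-yl with naphthalen-2-yl on a saturated ring carbon, which is a different place. Going by the values given here, no measured step changes the group that differs here, so the data give no direction, and no step beyond the scatter is expected in this assay.

This expectation amounts to an estimated 1.2-fold higher number from compound 3 to compound 4 (0.06 log units; within the scatter). For compound 4 the estimated value is 350 nM, with an expected range of 120 nM to 1000 nM.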

Compound 4, dissociation constant: 166 nM
Estimate against measurement, compound 4: 2.1-fold (0.32 log units) above, within the range that was stated.
By their numbers in this assay, from the lowest: compounds 4 and 3 (each within the scatter of the next); then compounds 1 and 2 (each within the scatter of the next).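

In this assay, for the compounds shown here, the first measured change at this position, 2-fluorophenyl in place of 4-methoxyphenyl on an oxygen on a saturated carbon, stays within the scatter (a 1.8-fold lower number from compound 3 to compound 4 (0.26 log units; within the scatter)). The hydrogen-bond acceptor counted in 4-methoxyphenyl is absent from 2-fluorophenyl, and this exchange did not move the number beyond the scatter. Nothing shown here gives a reason for this result.

Going by these compounds alone, the single step changes both the kind of substituent on the aromatic ring and its place, so the contribution of each remains unseparated. The compounds shown also leave open how the number would respond to an unsubstituted phenyl, to 4-fluorophenyl, or to a ring carrying an amine or a carboxylic acid on that oxygen.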